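Swapping the Amide Substituent of a Bis-Sulfonamide Piperidine

This account rests on a few compounds, and the source may have more. Where it says the series, first, only, none or still open, it means among the compounds named here.

Measured so far:
- compound 1 `CCN(CC)S(=O)(=O)c1ccc(S(=O)(=O)N2CCC[C@@H](C(=O)N[C@@H]3CCN(C(=O)OC(C)(C)C)C3)C2)cc1`: 200 nM
- compound 2 `CCOC(=O)C1CCN(S(=O)(=O)c2ccc(S(=O)(=O)N(CC)CC)cc2)CC1`: 27200 nM
- compound 3 `CCN(CC)S(=O)(=O)c1ccc(S(=O)(=O)N2CCC[C@@H](C(=O)N(C)C(C)C)C2)cc1`: 6200 nM

In a functional assay on MIA PaCa-2 cells (Homo sapiens) for inhibition, read by MTT assay, with a stated time of 7 days (on this read-out higher numbers stand for weaker inhibition and lower numbers for stronger inhibition), compound 3 stands second highest of the three numbers, beyond the scatter above compound 1 and beyond the scatter below compound 2. Compound 4 `CCN(CC)S(=O)(=O)c1ccc(S(=O)(=O)N2CCC[C@@H](C(=O)NC3CN(C(=O)C4CC4)C3)C2)cc1` differs from compound 3 in one place: (1-(cyclopropylcarbonyl)azetidin-3-yl)amino in place of isopropyl(methyl)amino on a carbonyl carbon. Going by the values given here, no pair of measured compounds differs in exactly this way, so the step is open. The amide end of compound 1 resembles that of compound 4 more than that of compound 3 does. Because compound 1 gives 200 nM, compound 4 is expected to move toward a lower number, giving an estimated step of a 14-fold lower number from compound 3 to compound 4 (1.14 log units; beyond the scatter). Compound 4 is therefore estimated at 450 nM, within 110 nM to 1800 nM.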

Compound 4, half-maximal inhibitory concentration: 2800 nM
Beside the measured number, compound 4's estimate is 6.2-fold (0.79 log units) below it; the whole stated range lies below it.
By their numbers in this assay, from the lowest: compound 1; then compound 4; then compound 3; then compound 2.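

In this assay, putting (1-(cyclopropylcarbonyl)azetidin-3-yl)amino in place of isopropyl(methyl)amino gives only a 2.2-fold lower number from compound 3 to compound 4 (0.35 log units; beyond the scatter). Exchanging 1-(tert-butoxycarbonyl)pyrrolidin-3-yl for 1-(cyclopropylcarbonyl)azetidin-3-yl on the amide-type nitrogen gives a much larger step, a 14-fold higher number from compound 1 to compound 4 (1.15 log units; beyond the scatter), so having an amide hydrogen and a ring in this position does not by itself reach the number of compound 1. No measurement here explains either step.

The ring and its carbonyl substituent change together in the larger step. A 1-(tert-butoxycarbonyl)azetidin-3-yl group would show which of the two matters more.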